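The source may hold more compounds than are shown below. What is called first, only, known or untested is meant among the compounds shown, and "the series" means these compounds.

Measured so far:
compound 1 `CCCCCCCNC[C@@H]1OC[C@H](N)[C@H]1O` — in a functional assay on PC-3 cells (Homo sapiens) for antiproliferative activity, read by MTT assay, with a stated time of 72 h (a lower number here means a stronger inhibitor, a higher number a weaker inhibitor), compound 1 gives only a limit, > 128000 nM.
compound 2 `CCCCCCCCNC[C@@H]1OC[C@H](N)[C@@H]1O` — in this assay compound 2 gives 13800 nM.

Among the compounds with values here, compound 2 holds the only actual number in this assay; the other value shown is a limit, (the limit of > 128000 nM in this assay, at which 1 of the 2 values shown sits). Compound 1 and compound 2 differ in more than one place, so no single step can be read from them. Compound 3 `CCCCCCCNC[C@@H]1OC[C@H](N)[C@@H]1O` differs from compound 2 in one place: hydrogen in place of methyl on a saturated chain carbon, seven bonds along the chain from an amine nitrogen. Within the data shown here, with no measured step of this kind, a modest weakening is expected, a 2.2-fold higher number from compound 2 to compound 3 (0.34 log units; beyond the scatter), in this assay. Compound 3 is therefore estimated at 30000 nM, between 9000 nM and 128000 nM.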

Compound 3, half-maximal inhibitory concentration: 22400 nM
Beside the measured number, compound 3's estimate is 1.3-fold (0.13 log units) above it, and the stated range covers the measured number.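

In this assay, hydrogen in place of methyl at this place on the chain gives a difference that cannot be told from the scatter: a 1.6-fold higher number from compound 2 to compound 3 (0.21 log units; within the scatter). A change in the drawn configuration at one saturated ring carbon, with the same atoms and bonds, gives a clearer step: an at least 5.7-fold lower number from compound 1 to compound 3 (0.75 log units; beyond the scatter). Compound 1 gives only a limit, > 128000 nM.

On these data alone, whether a phenyl group or a carboxylic acid in place of this methyl would shift the number remains open. So does the effect of that configuration on a longer chain.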